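From ethoxycarbonyl to carbamoyl: the step to compound 4

The source may report more compounds than this note shows. Statements on the series, on what has been measured and on what is new or still open speak of the compounds shown alone.

In a functional assay on HeLa cells (Homo sapiens) (on this read-out lower numbers stand for an effect already at smaller amounts and higher numbers for an effect only at larger amounts of compound), compound 2 `CCOC(=O)c1cc(CI)nn1C1O[C@@H](COC(C)=O)[C@H](OC(C)=O)[C@@H](OC(C)=O)[C@@H]1OC(C)=O` gives 2.5 ug/mL, and compound 3 `CCOC(=O)c1cc(CI)nn1[C@@H]1O[C@H](COC(C)=O)[C@@H](OC(C)=O)[C@H]1OC(C)=O` gives 5.5 ug/mL. Compound 3 thus holds the higher of these two numbers, and its gap to compound 2 lies beyond the scatter. For compound 1 `NC(=O)c1cc(CCl)[nH]n1`, which carries a carbamoyl group, the reading > 100 ug/mL is a limit and not a number.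

Compound 4 `CC(=O)OC[C@H]1O[C@@H](n2nc(CI)cc2C(N)=O)[C@H](OC(C)=O)[C@@H]1OC(C)=O` departs from compound 3 by a single change, amino in place of ethoxy on a carbonyl carbon, which turns ethoxycarbonyl into carbamoyl (amino in place of ethoxy on a carbonyl carbon). Within the data shown here, no measured pair shows this change on its own. Among the measured compounds shown here, the only guide to direction is compound 1 at > 100 ug/mL, the one measured compound with carbamoyl, and it offers a limit alone. A moderate move towards higher numbers is therefore expected, an estimated 2.2-fold higher number from compound 3 to compound 4 (0.34 log units; beyond the scatter). For compound 4 the expected value in this assay is 12 ug/mL, with an estimated range from 3.5 ug/mL to 50 ug/mL.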

Compound 4, concentration for half-maximal effect: 1.5 ug/mL
Compound 4: the middle estimate sits 8.0-fold (0.90 log units) above what was measured; the measured number lies below the stated range.
By their numbers in this assay, from the lowest: compounds 4 and 2 (each within the scatter of the next); then compound 3. At a limit, above all of these: compound 1.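

Among these compounds, the first reading of this change on its own comes from the core shared by compound 3 and compound 4: in this assay, amino in place of ethoxy on a carbonyl carbon gives a 3.7-fold lower number from compound 3 to compound 4 (0.56 log units; beyond the scatter). On this core, then, the ethoxycarbonyl group is not needed for an effect at small amounts of compound, and carbamoyl at the same place moves the number down rather than up. Nothing available here bears on why this single exchange lowers the number.

One step on one core cannot show whether the same exchange would move the number the same way on the core of compound 2. It also leaves open how other groups on this carbonyl carbon would read, such as hydroxy, which would give a carboxylic acid, or dimethylamino.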